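Chain extension in two linker series

The compounds below may be only part of what the source reports. "The series", "measured", "known", "first", "only" and "open" are said of these compounds alone.

Compound 1 `CN(C)C(=O)c1cc2cnc(Nc3ccc(S(=O)(=O)NCCCCCCN=C=S)cc3)nc2n1C1CCCC1` and compound 2 `CN(C)C(=O)c1cc2cnc(Nc3ccc(S(=O)(=O)NCCCCCCCN=C=S)cc3)nc2n1C1CCCC1` are built on the same core and differ in one place: a group of 4 heavy atoms (2 carbon, 1 nitrogen, 1 sulfur; no ring) in place of a group of 3 heavy atoms (1 carbon, 1 nitrogen, 1 sulfur; no ring), on a saturated chain carbon, six bonds along the chain from a sulfonamide nitrogen. In a functional assay on A549 cells (Homo sapiens) for inhibition, read by CCK-8 assay, with a stated time of 72 h, tested at 1 uM (on this read-out lower numbers stand for a weaker effect and higher numbers for a stronger effect at the one concentration tested), compound 1 gives 49.5%, while compound 2 gives 32.6%. The step is a number 16.9 percentage points lower from compound 1 to compound 2 (beyond the scatter).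

Compound 3 `CN(C)C(=O)c1cc2cnc(Nc3ccc(C(=O)NCCCN=C=S)cc3O)nc2n1C1CCCC1` carries a different core and linker; the difference between the core of compound 3 and that of compound 1 is not broken down here. In this assay compound 3 gives 55.9%, which lies within the scatter of compound 1 and beyond the scatter relative to compound 2.

Compound 4 `CN(C)C(=O)c1cc2cnc(Nc3ccc(C(=O)NCCCCN=C=S)cc3O)nc2n1C1CCCC1` has not yet been measured in this assay. It differs from compound 3 as follows: a group of 4 heavy atoms (2 carbon, 1 nitrogen, 1 sulfur; no ring) in place of a group of 3 heavy atoms (1 carbon, 1 nitrogen, 1 sulfur; no ring), on a saturated chain carbon, three bonds along the chain from an amide-type nitrogen. This is the same kind of change as that from compound 1 to compound 2, not the same change: there the group sits six bonds along the chain from a sulfonamide nitrogen, here three bonds along the chain from an amide-type nitrogen, so the surroundings of the place differ.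

Going by the values given here, only one earlier instance of this kind of change is available, and it sits on another linker. The expected step from compound 3 to compound 4 is a number 11.9 percentage points lower from compound 3 to compound 4 (beyond the scatter), set in the same direction as but smaller than the earlier step because a number 16.9 percentage points lower from compound 1 to compound 2 (beyond the scatter) was measured in different surroundings. Compound 4 is therefore estimated at 44% in this assay, with a range from 30% to 58%.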

Compound 4, a percentage reported as inhibition, at one concentration (the size of the read-out at that concentration, not a potency): 30.3%
Compound 4: middle estimate off by 13.7 percentage points, on the high side; the range from low to high includes it.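

Notes on the chain extension: in this assay, the group of 4 heavy atoms in place of the group of 3 heavy atoms again gives a lower number, a number 25.6 percentage points lower from compound 3 to compound 4 (beyond the scatter), and the step on this core does not differ from the earlier one: the same change on two cores in this assay, a number 16.9 percentage points lower (beyond the scatter) from compound 1 to compound 2 and a number 25.6 percentage points lower (beyond the scatter) from compound 3 to compound 4, 8.7 percentage points apart, within the scatter of two such steps

On these two pairs, the change therefore carries from one core to the other in direction and, within the scatter, in size, even though the surroundings of the place differ. Going by these compounds alone, this rests on only two pairs at one concentration, so it gives no potency and no rule for a further core, and it cannot separate the effect of the core from that of the linker or of the chain length at which the change is made.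

Still open, from the compounds shown here alone, is whether the fall continues on a longer chain in the amide-linked series, or whether it flattens out. Also open, going by these compounds, is how either core behaves with an amine or a carboxylic acid in the place of the group at the end of the chain, which would show whether the step belongs to the chain length alone or depends on that end group.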